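The compounds below may be only part of what the source reports. "The series", "measured", "known", "first", "only" and "open" are said of these compounds alone.

Going by the values given here, compound 1 `CCCS(=O)(=O)NC(=O)c1cc(COc2ccc(-c3ccc(OC)cc3)cc2)c(C)o1` has the lower of the two numbers so far in an assay on cells for displacement of a labelled ligand from prostaglandin E2 receptor EP4 subtype (Homo sapiens), read by scintillation counting (on this read-out lower numbers stand for stronger inhibition and higher numbers for weaker inhibition), where compound 1 gives 5 nM. Compound 2 `Cc1oc(CCC(=O)O)cc1COc1ccc(-c2ccccc2)cc1` gives 80 nM in this assay, a higher number by a margin beyond the scatter. Compound 3 `COc1ccc(-c2ccc(OCc3cc(C(=O)NS(=O)(=O)Cc4ccccc4)oc3C)cc2)cc1` differs from compound 1 in one place: phenyl in place of ethyl on a saturated chain carbon bound to a sulfonyl sulfur. Among the compounds with values here, no measured pair shows this change, so the step expected from compound 1 to compound 3 in this assay is no change at the digits printed from compound 1 to compound 3 (within the scatter), none beyond the scatter. Compound 3 is therefore estimated at 5 nM in this assay, within a range from 1.5 nM to 15 nM.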

Compound 3, inhibition constant: 3 nM
Beside the measured number, compound 3's estimate is 1.7-fold (0.22 log units) above it; low and high end bracket the measured number.
By their numbers in this assay, from the lowest: compounds 3 and 1 (each within the scatter of the next); then compound 2.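

Putting phenyl in place of ethyl on a saturated chain carbon bound to a sulfonyl sulfur gives a 1.7-fold lower number from compound 1 to compound 3 (0.22 log units; within the scatter) in this assay, so the number does not move beyond the scatter. This place therefore accepts benzylsulfonyl as well as propylsulfonyl, although the entering group brings 6 heavy atoms and an aromatic ring where the leaving group has 2 heavy atoms and no ring. Nothing available explains this tolerance. As far as these compounds go, it remains open whether an amine or a carboxylic acid on this chain carbon would leave the number unchanged. From the compounds shown here alone, a longer chain carrying the phenyl is equally open.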